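This account rests on a few compounds, and the source may have more. Where it says the series, first, only, none or still open, it means among the compounds named here.

Measured compounds:
Compound 1 `COc1ccc(NC(=O)c2cc3cc(OC)c(OCCCOc4no[n+]([O-])c4S(=O)(=O)c4ccccc4)cc3oc2=O)cc1` gives 5470 nM in an ADME assay on MCF-10A cells (Homo sapiens) for cytotoxicity, read by MTT assay, with a stated time of 48 h; on this read-out higher numbers stand for weaker inhibition and lower numbers for stronger inhibition.
Compound 2 `COc1cc2cc(N)c(=O)oc2cc1OCCCOc1no[n+]([O-])c1S(=O)(=O)c1ccccc1` gives 6450 nM in this assay.
Compound 3 `COc1cc2cc(C(=O)NCc3ccc(F)cc3)c(=O)oc2cc1OCCCOc1no[n+]([O-])c1S(=O)(=O)c1ccccc1` gives 8460 nM in this assay.

Compound 3 carries the highest of the three numbers, yet its separation from the others is small: a 1.3-fold higher number from compound 2 to compound 3 (0.12 log units; within the scatter) and a 1.5-fold higher number from compound 1 to compound 3 (0.19 log units; within the scatter), both within the scatter. The step from compound 3 to compound 4 `COc1cc2cc(C(=O)NCCCc3ccccc3)c(=O)oc2cc1OCCCOc1no[n+]([O-])c1S(=O)(=O)c1ccccc1` changes the amide substituent once more: phenethyl in place of 4-fluorophenyl on a saturated chain carbon bound to an amide-type nitrogen. The measured steps that bear on it are those that already rework the same position, namely a 1.5-fold higher number from compound 1 to compound 3 (0.19 log units; within the scatter) and a 1.3-fold higher number from compound 2 to compound 3 (0.12 log units; within the scatter); neither moves this assay beyond the scatter, and the remaining step, a 1.2-fold higher number from compound 1 to compound 2 (0.07 log units; within the scatter), is likewise flat. Nothing among these three compounds therefore suggests that exchanging one benzyl-type group for a longer one on the amide nitrogen should shift cytotoxicity. The expectation for compound 4 is a step of a 1.1-fold lower number from compound 3 to compound 4 (0.02 log units; within the scatter), essentially none beyond the scatter. Compound 4 is accordingly estimated at 8000 nM, with a range of 4000 nM to 16000 nM.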

Compound 4, half-maximal inhibitory concentration: 5330 nM
For compound 4 the middle estimate is 1.5-fold (0.18 log units) above the measured one; the range from low to high includes it.
By their numbers in this assay, from the lowest: compounds 4, 1, 2 and 3 (each within the scatter of the next).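

Exchanging 4-fluorobenzyl for 3-phenylpropyl on the amide-type nitrogen gives a 1.6-fold lower number from compound 3 to compound 4 (0.20 log units; within the scatter) in this assay and thus no change that can be read, so this position accepts 3-phenylpropyl as it accepts the two earlier groups. Measured against the other two compounds, the same group gives a 1.2-fold lower number from compound 2 to compound 4 (0.08 log units; within the scatter) when (3-phenylpropyl)carbamoyl stands in place of amino and a 1.0-fold lower number from compound 1 to compound 4 (0.01 log units; within the scatter) when 3-phenylpropyl stands in place of 4-methoxyphenyl on the amide-type nitrogen. Across amino and all three amide substituents, then, the four compounds remain within the scatter of one another in this cytotoxicity read-out.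

On these data alone, whether a tertiary amine or a carboxylic acid at the end of the amide chain, or a chain longer than 3-phenylpropyl, would move the number beyond the scatter stays open. Nothing shown here offers an explanation for these values.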